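The compounds below may be only part of what the source reports. "The series", "measured", "known", "first", "only" and "open" are said of these compounds alone.

Compound 3 `CC(C)=CCC/C(C)=C/CC1Cc2c(OC(=O)Nc3ccccc3F)cc(=O)n(CCCO)c2CC1(C)C` gives 0% in a functional assay on PANC-1 cells (Homo sapiens) for inhibition, read by MTT assay, with a stated time of 24 h, tested at 10 uM; a lower number here means less inhibition, a higher number more inhibition at the concentration tested (going by the name of the read-out); it stands level with compound 2 `COc1ccc(OCCCOc2cc(=O)n(CCCO)c3c2CC(C/C=C(\C)CCC=C(C)C)C(C)(C)C3)cc1`, which gives 0%, the two together the lowest of the three numbers shown, while compound 1 `CC(C)=CCC/C(C)=C/COc1cc(=O)n(CCCO)c2c1CC(C/C=C(\C)CCC=C(C)C)C(C)(C)C2` gives 3.1%, with a number 3.1 percentage points lower from compound 1 to compound 3 (within the scatter) and no change at the digits printed from compound 2 to compound 3 (within the scatter) both within the scatter. Compound 4 `CC(C)=CCC/C(C)=C/CC1Cc2c(OC(=O)Nc3ccc(Cl)c(Cl)c3)cc(=O)n(CCCO)c2CC1(C)C` differs from compound 3 by 3,4-dichlorophenyl in place of 2-fluorophenyl on an amide-type nitrogen. Among the compounds with values here, no measured step alters the group on the amide-type nitrogen; the two steps that install the (2-fluorophenyl)carbamoyl group, a number 3.1 percentage points lower from compound 1 to compound 3 (within the scatter) and no change at the digits printed from compound 2 to compound 3 (within the scatter), lie within the scatter, and the series so far shows no movement at all. For compound 4 the step of a number 2 percentage points higher from compound 3 to compound 4 (within the scatter) is therefore expected to stay within the scatter. Compound 4 is estimated at 2%, with a range from 0% to 12%.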

Compound 4, a percentage reported as inhibition, at one concentration (the size of the read-out at that concentration, not a potency): 0%
Estimate against measurement, compound 4: 2 percentage points above; measured number inside the range.
By their numbers in this assay, from the lowest: compounds 2, 3, 4 and 1 (each within the scatter of the next).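

In this assay, within the data shown here, the one measured step on the amide-type nitrogen, 3,4-dichlorophenyl in place of 2-fluorophenyl, gives no change at the digits printed from compound 3 to compound 4 (within the scatter), so this swap of halogen-bearing phenyl groups leaves the reading unmoved. The (3,4-dichlorophenyl)carbamoyl group on the oxygen on an aromatic ring reads no differently from the groups it replaces, with no change at the digits printed from compound 2 to compound 4 (within the scatter) and a number 3.1 percentage points lower from compound 1 to compound 4 (within the scatter). No measurement at hand offers an explanation for these readings.

Still open, as far as these compounds go, is whether an amine or a carboxylic acid on the phenyl ring would move the number. A longer chain between the amide-type nitrogen and that ring is equally untested by these compounds.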